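This account rests on a few compounds, and the source may have more. Where it says the series, first, only, none or still open, it means among the compounds named here.

Measured so far:
compound 1 `COc1ccc(C2C(C#N)=C(N)N(c3cc(OC)c(OC)c(OC)c3)C3=C2C(=O)CC(C)(C)C3)cc1` gives 15%
compound 2 `COc1cc(N2C(N)=C(C#N)C(c3cccs3)C3=C2CC(C)(C)CC3=O)cc(OC)c1OC` gives 20%

Among the compounds with values here, in a functional assay on Ehrlich cells (Mus musculus) for cytotoxicity, tested at 100 ug/mL (a lower number here means a weaker effect, a higher number a stronger effect of the compound at the concentration tested), compound 2 holds the highest of the two numbers, with compound 1 nearest; the single step between them, a number 5 percentage points higher from compound 1 to compound 2 (within the scatter), does not leave the scatter, so the two measured values show no real difference.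

Compound 3 `COc1cc(N2C(N)=C(C#N)C(c3ccc(O)cc3)C3=C2CC(C)(C)CC3=O)cc(OC)c1OC` differs from compound 2 by 4-hydroxyphenyl in place of thiophen-2-yl on a saturated ring carbon. Within the data shown here, the only measured step bears on the same saturated ring carbon: exchanging 4-methoxyphenyl for thiophen-2-yl moved this assay by a number 5 percentage points higher from compound 1 to compound 2 (within the scatter). Among the measured compounds shown here, no step with a 4-hydroxyphenyl group at that place has been measured, so the expectation rests on that one small step alone. The change from compound 2 to compound 3 is therefore expected to bring a number 2 percentage points lower from compound 2 to compound 3 (within the scatter), no shift beyond the scatter in either direction.

For compound 3 in this assay the estimate is 18%, with a range from 6% to 32%.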

Compound 3, a percentage reported as activity, at one concentration (the size of the read-out at that concentration, not a potency): 100%
Beside the measured number, compound 3's estimate is 82 percentage points below it, and the stated range ends below it.
By their numbers in this assay, from the lowest: compounds 1 and 2 (each within the scatter of the next); then compound 3.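

In this assay the group on the saturated ring carbon proves decisive: 4-hydroxyphenyl in place of thiophen-2-yl gives a number 80 percentage points higher from compound 2 to compound 3 (beyond the scatter), whereas the earlier exchange at this place stayed within the scatter. The closest comparison is a change of one small group, as hydrogen in place of methyl on an oxygen on an aromatic ring gives a number 85 percentage points higher from compound 1 to compound 3 (beyond the scatter), so among these three compounds the high value goes with the free hydroxy group and not with a six-membered aromatic ring alone. No measured evidence on the cause of this jump is available for these compounds.

Going by these compounds, whether an amine or a carboxylic acid on that phenyl ring would keep the high value stays open. On these data alone, with a single test concentration, the potency of compound 3 also stays open.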